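This account rests on a few compounds, and the source may have more. Where it says the series, first, only, none or still open, it means among the compounds named here.

Measured in a functional assay on HT-1080 cells (Homo sapiens) for cytotoxicity, read by MTT assay, with a stated time of 72 h; on this read-out higher numbers stand for weaker inhibition and lower numbers for stronger inhibition:
- Compound 1 `COc1ccc(/C=C2\CCC/C(=C\c3ccc(Cl)cc3)C2=O)cc1OC` gives 4800 nM
- Compound 2 `COc1cccc(/C=C2\CCC/C(=C\c3ccc(OC)c(OC)c3)C2=O)c1` gives 4600 nM
- Compound 3 `COc1ccc(/C=C2\CCC/C(=C\c3ccc(O)cc3)C2=O)cc1OC` gives 16800 nM

Compound 2 belongs with compound 1 at the low end of these numbers, the gap between them being a 1.0-fold lower number from compound 1 to compound 2 (0.02 log units; within the scatter). Compound 3 stands apart, with a 3.7-fold higher number from compound 2 to compound 3 (0.56 log units; beyond the scatter).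

Compound 4 `COc1ccc(/C=C2\CCC/C(=C\c3ccc(OC)c(OC)c3)C2=O)cc1OC` is compound 2 with methoxy in place of hydrogen on an aromatic carbon, ortho to a methoxy group and para to a large group (methoxy in place of hydrogen on an aromatic carbon). Among the compounds with values here, no measured pair isolates this change. The closest evidence is the exchange of one aromatic ring between two compounds, which gave a 1.0-fold lower number from compound 1 to compound 2 (0.02 log units; within the scatter). Within the data shown here, the only larger steps, a 3.5-fold higher number from compound 1 to compound 3 (0.54 log units; beyond the scatter) and a 3.7-fold higher number from compound 2 to compound 3 (0.56 log units; beyond the scatter), are modest and both end at the one compound carrying hydroxy, which compound 4 lacks, so they offer little guidance here. No step beyond the scatter is therefore expected in this assay. The expected change is small, an estimated 1.1-fold higher number from compound 2 to compound 4 (0.04 log units; within the scatter). For compound 4 the estimated value is 5000 nM, with an expected range of 2000 nM to 13000 nM.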

Compound 4, half-maximal inhibitory concentration: 3000 nM
Compound 4: middle estimate off by 1.7-fold (0.22 log units), on the high side; measured number inside the range.
By their numbers in this assay, from the lowest: compounds 4, 2 and 1 (each within the scatter of the next); then compound 3.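

In this assay, methoxy in place of hydrogen on an aromatic carbon, ortho to a methoxy group and para to a large group, gave a 1.5-fold lower number from compound 2 to compound 4 (0.19 log units; within the scatter). The earlier compounds shown here held no pair that isolated this change, and this pair shows that a methoxy group can enter at this position of compound 2 without a step beyond the scatter, so that neither a gain nor a loss can be claimed for it in this assay. Nothing at hand gives a reason for this outcome.

The compounds shown leave open whether a larger or different group at the same position, such as an ethoxy group, an amine or a carboxylic acid, would also stay within the scatter of compound 2. They also leave open whether the same exchange of hydrogen for methoxy would stay within the scatter on a compound whose other aromatic ring carries a hydroxy or a chloro group, as in compound 3 and compound 1.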